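Notes on a 2-methoxyphenyl analogue in the series

This account rests on a few compounds, and the source may have more. Where it says the series, first, only, none or still open, it means among the compounds named here.

Values so far in a functional assay on B16 cells (Mus musculus), read by spectrophotometry, with a stated time of 3 days (on this read-out lower numbers stand for stronger inhibition and higher numbers for weaker inhibition), are these
compound 1 `CCNC(=S)N/N=C/c1cccc2ccccc12` gives 1100 nM here
compound 2 `COc1ccc(NC(=S)N/N=C/c2cccc3ccccc23)cc1` gives 860 nM here
compound 3 `COc1cccc(NC(=S)N/N=C/c2cccc3ccccc23)c1` gives 830 nM here

Compound 3 at 830 nM stands within the scatter of both other compounds, so the three numbers cannot be ranked. The next change is 2-methoxyphenyl in place of 3-methoxyphenyl on an amide-type nitrogen and leads to compound 4 `COc1ccccc1NC(=S)N/N=C/c1cccc2ccccc12` with 2-methoxyphenyl in place of 3-methoxyphenyl on an amide-type nitrogen.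

Going by the values given here, three measured steps bear on this change. The closest is a 1.0-fold lower number from compound 2 to compound 3 (0.02 log units; within the scatter) for the exchange of 4-methoxyphenyl and 3-methoxyphenyl, and it stays within the scatter. Replacing ethyl gave a 1.3-fold lower number from compound 1 to compound 2 (0.11 log units; within the scatter) with 4-methoxyphenyl and a 1.3-fold lower number from compound 1 to compound 3 (0.12 log units; within the scatter) with 3-methoxyphenyl, and both also stay within the scatter. Among the compounds with values here, no measured compound yet carries 2-methoxyphenyl, so this support is indirect and rests on only three compounds.

No step beyond the scatter is therefore expected in this assay for this change. The estimated step is a 1.1-fold higher number from compound 3 to compound 4 (0.04 log units; within the scatter) and no real shift is expected from it. Compound 4 is expected at 900 nM with an estimated range from 450 nM to 1800 nM on this read-out.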

Compound 4, half-maximal inhibitory concentration: 920 nM
Beside the measured number, compound 4's estimate is 1.0-fold (0.01 log units) below it; low and high end bracket the measured number.
By their numbers in this assay, from the lowest: compounds 3, 2, 4 and 1 (each within the scatter of the next).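

In this assay, 2-methoxyphenyl in place of 3-methoxyphenyl on the amide-type nitrogen gives a 1.1-fold higher number from compound 3 to compound 4 (0.04 log units; within the scatter) and 2-methoxyphenyl in place of 4-methoxyphenyl gives a 1.1-fold higher number from compound 2 to compound 4 (0.03 log units; within the scatter) so the 2-methoxyphenyl, 3-methoxyphenyl and 4-methoxyphenyl groups cannot be told apart on this read-out. With 2-methoxyphenyl in place of ethyl, the step is a 1.2-fold lower number from compound 1 to compound 4 (0.08 log units; within the scatter) and so none of the three methoxyphenyl groups separates from ethyl at this nitrogen, which makes the position flat across all four compounds shown. No supporting data are available that could account for this flat result.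

The compounds shown leave open whether a different kind of group on this nitrogen, such as a phenyl ring bearing an amine or a carboxylic acid, or a longer chain in place of ethyl, would give a step beyond the scatter. From the compounds shown here alone, all four compounds also carry the same core, and whether the flat picture at this nitrogen would hold with a changed core remains open.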